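Replacing a cyclic imide with a sulfonamide: expected cytotoxicity

The source may hold more compounds than are shown below. What is called first, only, known or untested is meant among the compounds shown, and "the series" means these compounds.

Measured compounds:
- compound 1, `CN1CCN(C[C@H]2CN(c3ccc(-n4cc(-c5ccccn5)cn4)c(F)c3)C(=O)O2)CC1`, gives 70 ug/mL in an ADME assay on HEK293-A cells (Homo sapiens) for cytotoxicity, read by MTT assay, with a stated time of 48 h; a lower number here means a stronger inhibitor, a higher number a weaker inhibitor
- compound 2, `COC(=O)CC1CCN(C[C@H]2CN(c3ccc(-n4cc(-c5ccccn5)cn4)c(F)c3)C(=O)O2)CC1`, gives 224 ug/mL in this assay
- compound 3, `O=C1CCC(=O)N1C[C@H]1CN(c2ccc(-n3cc(-c4ccccn4)cn3)c(F)c2)C(=O)O1`, gives > 400 ug/mL in this assay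

For compound 3 the reported value is a limit of the assay, not a number: the limit of > 400 ug/mL in this assay, at which 1 of the 3 values shown sits. Compound 3 therefore stands at the weak end of the three, with only a floor known.

Compound 4, `CS(=O)(=O)NC[C@H]1CN(c2ccc(-n3cc(-c4ccccn4)cn3)c(F)c2)C(=O)O1`, is the next step. It differs from compound 3 in one place: methanesulfonamido in place of 2,5-dioxopyrrolidin-1-yl on a saturated chain carbon bound to a saturated ring carbon.

The steps that reach compound 3 point the same way. From compound 1 the change was an at least 5.7-fold higher number from compound 1 to compound 3 (0.75 log units; beyond the scatter), and from compound 2 it was an at least 1.7-fold higher number from compound 2 to compound 3 (0.25 log units; that floor lies within the scatter), the second of these only a floor. Among the compounds with values here, no measured step swaps one small, uncharged group for another of similar kind, so the closest guide is that compound 2 and compound 3 sit near one another in this assay. For compound 4 a step of about an at least 1.0-fold lower number from compound 3 to compound 4 (0.02 log units; that floor lies within the scatter) is expected, that is, no clear movement beyond the scatter, with a real chance that only a limit is again reported. Compound 4 is thus estimated at 380 ug/mL, within 180 ug/mL to 700 ug/mL.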

Compound 4, half-maximal inhibitory concentration: 314 ug/mL
Compound 4: the middle estimate sits 1.2-fold (0.08 log units) above what was measured, within the range that was stated.
By their numbers in this assay, from the lowest: compound 1; then compounds 2 and 4 (each within the scatter of the next). At a limit, above all of these: compound 3.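

The methanesulfonamido group gives a measured number at this place, on a saturated chain carbon bound to a saturated ring carbon, whereas compound 3 is reported only as a limit: the limit of > 400 ug/mL in this assay, at which 1 of the 4 values shown sits.

Replacing the 2,5-dioxopyrrolidin-1-yl ring with methanesulfonamido removes the ring and adds 1 hydrogen-bond donor, and the result is an at least 1.2-fold lower number from compound 3 to compound 4 (0.10 log units; that floor lies within the scatter), so neither that ring nor the absence of a donor is needed for a high number in this assay. Methanesulfonamido in place of 4-((methoxycarbonyl)methyl)piperidin-1-yl gives a 1.4-fold higher number from compound 2 to compound 4 (0.15 log units; within the scatter), while in place of 4-methylpiperazin-1-yl it gives a 4.5-fold higher number from compound 1 to compound 4 (0.65 log units; beyond the scatter), which leaves the 4-methylpiperazin-1-yl group as the only one here set apart by a step beyond the scatter.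

From the compounds shown here alone, the true size of the gap between compound 3 and compound 4 stays open, with only a floor known for it. The compounds shown also do not tell where a carboxylic acid or a simple primary amine at this place would fall, or whether a longer chain on the sulfonyl group would keep the number in the same range.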